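Removing a Chlorine: Expected Cytotoxicity of Compound 4

The compounds below may be only part of what the source reports. "The series", "measured", "known", "first", "only" and "open" are said of these compounds alone.

Of the compounds shown here, three have been measured in an ADME assay on Vero cells (Chlorocebus sabaeus) for cytotoxicity, read by CellTiter-Glo and ATP content, with a stated time of 72 h; on this read-out higher numbers stand for lower toxicity in this test and lower numbers for higher toxicity in this test. Compound 1 `Nc1c(C2=NCCN2)cnn1-c1cccc(Cl)c1` is reported only as a limit of the assay, > 500000 nM. Compound 2 `Nc1c(C2=NCCN2)cnn1-c1cc(Cl)cc(Cl)c1` gives 257000 nM in this assay. Compound 3 `Nc1c(C2=NCCCN2)cnn1-c1ccc(Cl)c(Cl)c1` is likewise reported only as a limit, > 500000 nM. The difference between the core of compound 3 and the core of compound 2 is not broken down here.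

Going by the values given here, the single counted step among the measured compounds is hydrogen in place of chloro on an aromatic carbon, which gave an at least 1.9-fold higher number from compound 2 to compound 1 (0.28 log units; that floor lies within the scatter). Compound 4 `Nc1c(C2=NCCCN2)cnn1-c1ccc(Cl)cc1` has not yet been measured. It arises from compound 3 by hydrogen in place of chloro on an aromatic carbon, the same kind of change, though here the place is ortho to a chloro group rather than meta to one.

Compound 3 already sits at the limit, and because of the limit of > 500000 nM in this assay, at which 2 of the 3 values shown sit, a large shift from compound 3 to compound 4 seems unlikely. The step from compound 3 to compound 4 is therefore expected to be a number no higher from compound 3 to compound 4 (the limit leaves the size open). Compound 4 is estimated to give 500000 nM in this assay, most plausibly between 250000 nM and 1000000 nM, and probably again only as a limit.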

Compound 4, half-maximal cytotoxic concentration: > 500000 nM
Compound 4 gave a limit, no number; the forecaster's own chance of this, stated with the estimate: 75%; the middle value lies on the limit itself.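

In this assay compound 3 gives > 500000 nM, which is a limit of the assay and not a number. Compound 4 gives > 500000 nM, again a limit, so no step can be read between compound 3 and compound 4. The compounds shown leave open what hydrogen in place of chloro does to the number on the core of compound 3, as the values stop at one limit: the limit of > 500000 nM in this assay, at which 3 of the 4 values shown sit.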